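Benzothiazole to dibromophenyl on the amide nitrogen

This account rests on a few compounds, and the source may have more. Where it says the series, first, only, none or still open, it means among the compounds named here.

Compound 3 `Cc1cccc2sc(NC(=O)COc3ccc4cc(/C=C5/SC(=O)NC5=O)ccc4c3)nc12` gives the lowest number of the three compounds measured in an assay on isolated protein for inhibition of histone deacetylase 4 (Homo sapiens), with a stated time of 1 h (on this read-out higher numbers stand for weaker inhibition and lower numbers for stronger inhibition), at 1200 nM. Compound 1 `O=C(COc1ccc2cc(/C=C3/SC(=O)NC3=O)ccc2c1)Nc1ccc(F)cc1F` gives 3900 nM and compound 2 `O=C(COc1ccc2cc(/C=C3/SC(=O)NC3=O)ccc2c1)Nc1cccc(C(F)(F)F)c1` gives 2500 nM; the steps of a 3.3-fold lower number from compound 1 to compound 3 (0.51 log units; beyond the scatter) and a 2.1-fold lower number from compound 2 to compound 3 (0.32 log units; beyond the scatter) both lie beyond the scatter, whereas a 1.6-fold lower number from compound 1 to compound 2 (0.19 log units; within the scatter) does not. Compound 4 `O=C(COc1ccc2cc(/C=C3/SC(=O)NC3=O)ccc2c1)Nc1ccc(Br)c(Br)c1` differs from compound 3 in one place: 3,4-dibromophenyl in place of 4-methyl-1,3-benzothiazol-2-yl on an amide-type nitrogen. The two steps that bear on this change are the ones ending at compound 3, in which 4-methyl-1,3-benzothiazol-2-yl gave a lower number than either 2,4-difluorophenyl or 3-(trifluoromethyl)phenyl on the amide-type nitrogen. Replacing it with 3,4-dibromophenyl is therefore expected to move the number back up, roughly to where compound 1 and compound 2 sit, though two examples are a thin basis and the estimate is held wide. Compound 4 is estimated at 2800 nM, within 1200 nM to 6500 nM, an expected step of a 2.3-fold higher number from compound 3 to compound 4 (0.37 log units; beyond the scatter).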

Compound 4, half-maximal inhibitory concentration: 4900 nM
For compound 4 the middle estimate is 1.8-fold (0.24 log units) below the measured one; the range from low to high includes it.
By their numbers in this assay, from the lowest: compound 3; then compounds 2, 1 and 4 (each within the scatter of the next).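

In this assay the 4-methyl-1,3-benzothiazol-2-yl group on the amide-type nitrogen now stands apart from a third aryl group, with a 4.1-fold higher number from compound 3 to compound 4 (0.61 log units; beyond the scatter). The 3,4-dibromophenyl group cannot be separated from the other two phenyl groups, with a 2.0-fold higher number from compound 2 to compound 4 (0.29 log units; within the scatter) and a 1.3-fold higher number from compound 1 to compound 4 (0.10 log units; within the scatter), so among these four compounds only the benzothiazole-bearing compound 3 gives a number beyond the scatter of the rest. Nothing shown here speaks to the reason for this difference. From the compounds shown here alone, whether the lower number belongs to the fused ring system or to its 4-methyl group remains open. Also open, going by these compounds, is what an unsubstituted 1,3-benzothiazol-2-yl, a pyridinyl ring or a phenyl ring carrying an amine would give on the same nitrogen.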